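Azido in place of hydroxy: compound 2 to compound 3

The compounds below may be only part of what the source reports. "The series", "measured", "known", "first", "only" and "open" are said of these compounds alone.

For the measured compounds named here, in a functional assay on MCF7 cells (Homo sapiens) for cytotoxicity, read by MTT assay, with a stated time of 2 h (on this read-out higher numbers stand for weaker inhibition and lower numbers for stronger inhibition), compound 2 `[N-]=[N+]=NCCOCCO[Si]1(OCCOCCO)n2c3c4ccccc4c2/N=C2\N=C(/N=c4/c5ccccc5/c(n41)=N/C1=N/C(=N\3)c3ccccc31)c1ccccc12` gives 3.7 nM, the lowest of the two numbers measured so far. Compound 1 `[N-]=[N+]=NCCOCCOCCO[Si]1(OCCOCCOCCN=[N+]=[N-])n2c3c4ccccc4c2/N=C2\N=C(/N=c4/c5ccccc5/c(n41)=N/C1=N/C(=N\3)c3ccccc31)c1ccccc12` gives 12 nM in this assay, a higher number by more than the scatter. Compound 3 `[N-]=[N+]=NCCOCCO[Si]1(OCCOCCN=[N+]=[N-])n2c3c4ccccc4c2/N=C2\N=C(/N=c4/c5ccccc5/c(n41)=N/C1=N/C(=N\3)c3ccccc31)c1ccccc12` is not yet measured; it differs from compound 2 by azido in place of hydroxy on a saturated chain carbon, two bonds along the chain from an oxygen on a saturated carbon. Going by the values given here, no measured pair isolates this change, so the step of a 1.9-fold higher number from compound 2 to compound 3 (0.28 log units; within the scatter) is an expectation only: a modest move toward a higher number that may well stay within the scatter. For compound 3 in this assay the expected value is 7 nM, with a range from 3 nM to 20 nM.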

Compound 3, half-maximal inhibitory concentration: 12 nM
The estimate for compound 3 lay 1.7-fold (0.23 log units) below the measured number; measured number inside the range.
By their numbers in this assay, from the lowest: compound 2; then compounds 1 and 3 (each within the scatter of the next).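

In this assay, azido in place of hydroxy on a saturated chain carbon, two bonds along the chain from an oxygen on a saturated carbon, gives a 3.2-fold higher number from compound 2 to compound 3 (0.51 log units; beyond the scatter). For the compounds shown here, this is the first change read in one place, and it shows that this chain end is not indifferent to the group it carries: the step lies beyond the scatter, with hydroxy giving the lower number.

From the compounds shown here alone, whether an amine or a carboxylic acid at this chain end would give a lower or a higher number stays open, as does whether the step holds on a longer chain. Nothing at hand gives a cause for the step.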